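The source may report more compounds than this note shows. Statements on the series, on what has been measured and on what is new or still open speak of the compounds shown alone.

Among the compounds with values here, compound 1 `Oc1cccc2c1CCCC2c1c[nH]cn1` gives the lower of the two numbers so far recorded in an assay on isolated protein for binding affinity to Alpha-1D adrenergic receptor (Rattus norvegicus), read by radioligand binding (a lower number here means a stronger inhibitor, a higher number a weaker inhibitor), namely 30.9 nM. Compound 2 `CCS(=O)(=O)Nc1cccc(Cc2c[nH]cn2)c1C`, built on a different core, gives 1000 nM in this assay, a gap from compound 1 that lies well beyond the scatter. Compound 3 `CN(c1cccc2c1CCCC2c1c[nH]cn1)S(C)(=O)=O` has not yet been measured; it differs from compound 1 in one place: methyl(methylsulfonyl)amino in place of hydroxy on an aromatic carbon. Within the data shown here, no step between measured compounds isolates this exchange. Compound 3 is expected to give a higher number in this assay, beyond the scatter, with the estimated step of a 9.7-fold higher number from compound 1 to compound 3 (0.99 log units; beyond the scatter). Compound 3 is estimated at 300 nM, within 60 nM to 1500 nM.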

Compound 3, inhibition constant: 708 nM
Estimate against measurement, compound 3: 2.4-fold (0.37 log units) below; the measured number falls inside the stated range.
By their numbers in this assay, from the lowest: compound 1; then compounds 3 and 2 (each within the scatter of the next).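

In this assay, the exchange of hydroxy for methyl(methylsulfonyl)amino on this aromatic carbon of the shared core gives a large step, a 23-fold higher number from compound 1 to compound 3 (1.36 log units; beyond the scatter), the only direct reading of this change among the compounds shown. At this position, the larger group without a hydrogen-bond donor thus goes with a much weaker result than hydroxy. No measurement shown accounts for the step. A single exchange cannot separate the loss of hydroxy from the entry of the new group. From the compounds shown here alone, how a methoxy group, an amine or the methylsulfonylamino group lacking the nitrogen methyl would read here remains open.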